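Replacing 2-Fluorophenyl with (4-Methylphenyl)carbonyl on the Hydrazine Nitrogen

The source may hold more compounds than are shown below. What is called first, only, known or untested is meant among the compounds shown, and "the series" means these compounds.

Three compounds share one core and differ only in the aryl group on the amine nitrogen. Compound 1 `O=C(NNc1ccccc1Cl)c1ccccc1NS(=O)(=O)c1cnc(O)nc1O` gives 14100 nM in a functional assay on OVCAR-3 cells (Homo sapiens) for antiproliferative activity, read by MTT assay, with a stated time of 24 h; on this read-out higher numbers stand for weaker inhibition and lower numbers for stronger inhibition. Compound 2 `O=C(NNc1cccc(Cl)c1)c1ccccc1NS(=O)(=O)c1cnc(O)nc1O` gives 5520 nM, and compound 3 `O=C(NNc1ccccc1F)c1ccccc1NS(=O)(=O)c1cnc(O)nc1O` gives 9570 nM. Going by the values given here, the only step beyond the scatter is a 2.6-fold lower number from compound 1 to compound 2 (0.41 log units; beyond the scatter). Compound 3 stands second highest of the three: the step of a 1.5-fold lower number from compound 1 to compound 3 (0.17 log units; within the scatter) and the step of a 1.7-fold higher number from compound 2 to compound 3 (0.24 log units; within the scatter) both lie within the scatter, so compound 3 cannot be separated from either neighbour.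

Compound 4 `Cc1ccc(C(=O)NNC(=O)c2ccccc2NS(=O)(=O)c2cnc(O)nc2O)cc1` takes a different route from compound 3: (4-methylphenyl)carbonyl in place of 2-fluorophenyl on an amine nitrogen. Among the compounds with values here, every measured step so far swaps one halogenated phenyl for another, on the same nitrogen; none exchanges the phenyl for a carbonyl-bearing group, so no step in hand bears directly on this change. With the three measured values lying close together and the two within-scatter steps around compound 3, the expectation is a step of no clear direction and likely within the scatter, written as a 1.1-fold lower number from compound 3 to compound 4 (0.03 log units; within the scatter). Compound 4 is therefore expected at about 9000 nM in this assay, within a range from 2500 nM to 32000 nM.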

Compound 4, half-maximal inhibitory concentration: 12900 nM
Compound 4: middle estimate off by 1.4-fold (0.16 log units), on the low side; low and high end bracket the measured number.
By their numbers in this assay, from the lowest: compounds 2, 3, 4 and 1 (each within the scatter of the next, the first and the last beyond it).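

In this assay, going by these compounds alone, the (4-methylphenyl)carbonyl group is the first on this amine nitrogen to carry a carbonyl, yet the change does not separate compound 4 from two of the halogenated phenyl compounds, with a 1.3-fold higher number from compound 3 to compound 4 (0.13 log units; within the scatter) and a 1.1-fold lower number from compound 1 to compound 4 (0.04 log units; within the scatter) both inside the scatter. So at this position, a phenyl ring attached directly to the nitrogen can give way to a ring held through a carbonyl with no step beyond the scatter from either compound, and only the 3-chlorophenyl compound stands apart, with a 2.3-fold higher number from compound 2 to compound 4 (0.37 log units; beyond the scatter), a modest step. Nothing measured on these groups beyond this read-out is available to account for these numbers.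

The compounds shown do not tell whether the carbonyl or the methyl group matters here, since the change brings in both at once and no compound carries one without the other. From the compounds shown here alone, it also remains open whether a simple acetyl group, with no ring, would hold up on this nitrogen, and whether a (3-chlorophenyl)carbonyl group would follow compound 2 or stay with compound 4.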